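Alkoxy chain extension on the aryl ring: working notes

The source may report more compounds than this note shows. Statements on the series, on what has been measured and on what is new or still open speak of the compounds shown alone.

Compound 1 `CCOc1ccc(-c2ncnn2-c2cc(OC)c(OC)c(OC)c2)cc1` is the reference of the series. In a functional assay on HeLa cells (Homo sapiens) for antiproliferative activity, read by MTT assay, with a stated time of 72 h (a lower number here means a stronger inhibitor, a higher number a weaker inhibitor), compound 1 gives 15 nM. Compound 2 `COc1cc(-n2ncnc2-c2ccc(OC(C)C)cc2)cc(OC)c1OC` carries methyl in place of hydrogen on a saturated chain carbon bound to an oxygen on an aromatic ring and a saturated chain carbon and in this assay compound 2 gives 600 nM; the step is a 40-fold higher number from compound 1 to compound 2 (1.60 log units; beyond the scatter). Compound 3 `COc1ccccc1-c1ncnn1-c1cc(OC)c(OC)c(OC)c1` differs from compound 1 by a change that is not broken down here. In this assay compound 3 reaches only a limit, > 10000 nM, the limit described under (the limit of > 10000 nM in this assay, at which 1 of the 3 values shown sits). Going by the values given here, compound 4 `CCOc1ccccc1-c1ncnn1-c1cc(OC)c(OC)c(OC)c1`, not yet measured, carries methyl in place of hydrogen on a saturated chain carbon bound to an oxygen on an aromatic ring; this is the same kind of change as the one between compound 1 and compound 2, though there the place was also bound to a saturated chain carbon. Among the compounds with values here, the step from compound 3 to compound 4 in this assay is expected as a step that the limit leaves unreadable from compound 3 to compound 4, set beside a 40-fold higher number from compound 1 to compound 2 (1.60 log units; beyond the scatter), because the only measured step of this kind, a 40-fold higher number from compound 1 to compound 2 (1.60 log units; beyond the scatter), weakened. Compound 4 is expected at 20000 nM in this assay, most likely between 5000 nM and 60000 nM.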

Compound 4, half-maximal inhibitory concentration: > 10000 nM
Compound 4 ended at the assay's limit (the forecaster's own chance of this, stated with the estimate: 75%); the middle value lies beyond the limit too.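

No step can be read between compound 3 and compound 4, as each value is only a limit: the limit of > 10000 nM in this assay, at which 2 of the 4 values shown sit.

Left open is what methoxy to ethoxy does to activity in this pair.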